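The compounds below may be only part of what the source reports. "The series", "measured", "known", "first", "only" and "open" are said of these compounds alone.

Of the compounds shown here, three built on a shared core have been tested in a functional assay on KB cells (Homo sapiens) for antiproliferative activity, read by sulforhodamine B assay, with a stated time of 72 h; a higher number here means a weaker inhibitor, a lower number a stronger inhibitor. Compound 1 `O=C1C=CCC/C1=C\c1ccc(OC(F)(F)F)cc1` gives 530 nM, compound 2 `COc1ccc(/C=C2\CCC=CC2=O)cc1[N+](=O)[O-]` gives 1360 nM, and compound 3 `Cn1cc(/C=C2\CCC=CC2=O)c2ccccc21` gives 4420 nM. Compound 3 therefore has the highest number of the three, which makes it the weakest inhibitor in this small set. Even its nearest neighbour, compound 2, lies lower by more than the usual scatter of repeated measurements.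

The next compound, compound 4 `CC(=O)n1cc(/C=C2\CCC=CC2=O)c2ccccc21`, keeps all of compound 3 except one group, with acetyl in place of methyl on an aromatic nitrogen. Among the compounds with values here, no two measured compounds differ in only one place, so no measured step shows what a swap of this kind does, and any forecast must stay loose. Within the data shown here, the only guide is the spread of the set: compound 3 sits at the top with 4420 nM, while compound 1 on the same core reaches 530 nM. A modest move to a lower number is expected, about the size of the usual scatter, an estimated 2.2-fold lower number from compound 3 to compound 4 (0.34 log units; beyond the scatter). For compound 4 the estimate is 2000 nM, with an expected range from 700 nM to 6000 nM.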

Compound 4, half-maximal inhibitory concentration: 4460 nM
Beside the measured number, compound 4's estimate is 2.2-fold (0.35 log units) below it; the range from low to high includes it.
By their numbers in this assay, from the lowest: compound 1; then compound 2; then compounds 3 and 4 (each within the scatter of the next).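

In this assay, putting acetyl in place of methyl on the aromatic nitrogen gives a 1.0-fold higher number from compound 3 to compound 4 (0.00 log units; within the scatter), so the two compounds cannot be told apart. Within the data shown here, this is the first step in the set between two compounds that differ in only one place, and it gives a direct reading at this nitrogen: a group with more heavy atoms, a double bond and a hydrogen-bond acceptor sits there with no separation between the two numbers. This single pair supports no rule for other groups at this nitrogen, and nothing available here bears on why the two numbers match.

The compounds shown leave open whether a plain hydrogen on this nitrogen, a longer chain such as butyl, or a chain ending in an amine or a carboxylic acid would also stay within the scatter of compound 3. They also leave open whether the same swap would give so small a step with a different group elsewhere on the shared core.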